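Replacing the Aryl Group on a Shared Core

The source may hold more compounds than are shown below. What is called first, only, known or untested is meant among the compounds shown, and "the series" means these compounds.

Three compounds share one core and differ only in the aromatic group attached to a ring nitrogen. Compound 1 `Cn1ccc2c(Oc3ccc(NC(=O)c4cn(-c5ccc(F)cc5)c5ccccc5c4=O)cc3F)ccnc21` carries one such group, but in a functional assay on MCF7 cells (Homo sapiens) for inhibition, read by MTT assay, with a stated time of 72 h (a lower number here means a stronger inhibitor, a higher number a weaker inhibitor), compound 1 has only "not determined" (no result reported), so no number is available for it. Within the data shown here, compound 2 `Cn1ccc2c(Oc3ccc(NC(=O)c4cn(-c5ccc(C(F)(F)F)cc5Cl)c5ccccc5c4=O)cc3F)ccnc21` carries a 2-chloro-4-(trifluoromethyl)phenyl and gives 190 nM in this assay; that is the only number available, so compound 2 stands alone as the single reference point, and no comparison between two measured compounds can be drawn. Compound 3 `COc1ccc(-n2cc(C(=O)Nc3ccc(Oc4ccnc5c4ccn5C)c(F)c3)c(=O)c3ccccc32)cc1` has not yet been measured. It differs from compound 2 in one place: 4-methoxyphenyl in place of 2-chloro-4-(trifluoromethyl)phenyl on an aromatic nitrogen. Among the measured compounds shown here, no step between measured compounds exists to calibrate a change of this kind, so the expectation rests on the value of compound 2 and on the size of the exchange alone. Swapping one aromatic group for a smaller one that brings in a hydrogen-bond acceptor is a considerable change, and the expected outcome in this assay is a weakening step clearly beyond the usual scatter. Compound 3 is therefore estimated at 600 nM, within a range from 150 nM to 3000 nM. This corresponds to an expected step of a 3.2-fold higher number from compound 2 to compound 3 (0.50 log units; beyond the scatter).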

Compound 3, half-maximal inhibitory concentration: 6720 nM
Estimate against measurement, compound 3: 11-fold (1.05 log units) below; measured number outside the range, above it.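

Among these compounds, the change from 2-chloro-4-(trifluoromethyl)phenyl to 4-methoxyphenyl on the aromatic nitrogen gives the first measured step at this position: in this assay it brings a 35-fold higher number from compound 2 to compound 3 (1.55 log units; beyond the scatter), which makes compound 3 the weaker inhibitor and shows that the group on this nitrogen can strongly shift the reading. The carbon-only six-membered aromatic ring stays in both compounds, so this large step accompanies a change in what that ring carries: chlorine and trifluoromethyl leave, and methoxy enters. No measurement shown here accounts for the step, and a single pair cannot tell whether the loss of chlorine, the loss of trifluoromethyl or the arrival of methoxy matters most.

On these data alone, compound 1 has no number, so its aryl group cannot yet be placed alongside these two, and it remains open how a ring carrying only chlorine, only trifluoromethyl or no substituent at all would read. Also open, as far as these compounds go, is how this position would respond to a ring bearing a dimethylamino group or a carboxylic acid, or to a longer chain such as ethoxy in place of methoxy.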